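Changing the Aryl Group on the Carbonyl: Two Measured, One Expected

This account rests on a few compounds, and the source may have more. Where it says the series, first, only, none or still open, it means among the compounds named here.

Compound 1 `COc1ccc(-c2cc3ccccc3nc2/C=C/C(=O)c2ccccc2)cc1` and compound 2 `COc1ccc(-c2cc3ccccc3nc2/C=C/C(=O)c2ccc(OC)c(OC)c2)cc1` share the same core and differ only in the group on the carbonyl carbon. In a functional assay on MDA-MB-231 cells (Homo sapiens) for antiproliferative activity, read by XTT assay, with a stated time of 72 h (a higher number here means a weaker inhibitor, a lower number a stronger inhibitor), compound 1 gives 860 nM, while compound 2 gives 4790 nM. For the measured compounds named here, the one step measured so far, a 5.6-fold higher number from compound 1 to compound 2 (0.75 log units; beyond the scatter), came from putting 3,4-dimethoxyphenyl in place of phenyl on a carbonyl carbon, and it leaves compound 2 with the higher of the two numbers, beyond the scatter from compound 1.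

Compound 3 `COc1ccc(-c2cc3ccccc3nc2/C=C/C(=O)c2sccc2N)cc1` has not yet been measured. It differs from compound 2 as follows: 3-aminothiophen-2-yl in place of 3,4-dimethoxyphenyl on a carbonyl carbon. Going by the values given here, the 3,4-dimethoxyphenyl group leaves, and the step that introduced it, a 5.6-fold higher number from compound 1 to compound 2 (0.75 log units; beyond the scatter), is the only measured step that bears on this change. Among the compounds with values here, no measured compound carries 3-aminothiophen-2-yl, so the contribution of that group is unknown. Removing the group that accompanied the weaker result gives some reason to expect a lower number than compound 2, though the new group could move the result either way. Compound 3 is therefore expected to give 1500 nM, within a range of 400 nM to 6000 nM, which corresponds to an expected step of a 3.2-fold lower number from compound 2 to compound 3 (0.50 log units; beyond the scatter).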

Compound 3, half-maximal inhibitory concentration: > 10000 nM
Compound 3: a limit, no number; the forecaster's own chance of this, stated with the estimate: 5%; middle value at least 6.6-fold (0.82 log units) from the limit.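

The reading of compound 3 in this assay is a limit and not a number: the limit of > 10000 nM in this assay, at which 1 of the 3 values shown sits. Putting 3-aminothiophen-2-yl on the carbonyl carbon gives an at least 2.0-fold higher number from compound 2 to compound 3 (0.31 log units; beyond the scatter), and measured against the unsubstituted phenyl group it gives an at least 11-fold higher number from compound 1 to compound 3 (1.06 log units; beyond the scatter). The earlier pair showed only that one substituted phenyl group raised the number, whereas this result shows that removing 3,4-dimethoxyphenyl does not by itself bring the number down, and that a second replacement for phenyl, this time a five-membered aromatic ring with one hetero atom and one hydrogen-bond donor, also raises it, leaving phenyl with the lowest number of the three groups shown.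

On these data alone, how far compound 3 lies beyond its limit remains open, as does whether the thiophene ring or its amine accounts for the step. Also open, as far as these compounds go, is what a thiophen-2-yl group without the amine, or a phenyl group carrying a single methoxy group or a fluorine atom, would give on this carbonyl carbon.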